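Replacing the 1,3-benzothiazol-5-yl group of compound 2

This account rests on a few compounds, and the source may have more. Where it says the series, first, only, none or still open, it means among the compounds named here.

In an ADME assay (liver) for metabolic stability, with Liver microsome (Homo sapiens) as the target, using microsomes and NADPH, with a stated time of 30 min, tested at 1 uM (a lower number here means slower removal, a higher number faster removal of the compound), compound 1 `Nc1ccc(S(=O)(=O)N2CCN(c3ncc(C(O)(C(F)(F)F)C(F)(F)F)cc3-c3ccc4sccc4c3)CC2)cn1` gives 48 mL.min-1.g-1 and compound 2 `Nc1ccc(S(=O)(=O)N2CCN(c3ncc(C(O)(C(F)(F)F)C(F)(F)F)cc3-c3ccc4scnc4c3)CC2)cn1` gives 39 mL.min-1.g-1 on the same scale. For the measured compounds named here, these two numbers lie within the scatter of each other, so compound 2 stands level with the only other compound measured so far.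

Compound 3 `Cc1nc2cc(-c3cc(C(O)(C(F)(F)F)C(F)(F)F)cnc3N3CCN(S(=O)(=O)c4ccc(N)nc4)CC3)ccc2o1` differs from compound 2 in one place, where 2-methyl-1,3-benzoxazol-5-yl stands in place of 1,3-benzothiazol-5-yl on an aromatic carbon, ortho to a large group (2-methyl-1,3-benzoxazol-5-yl in place of 1,3-benzothiazol-5-yl on an aromatic carbon). The rest of the molecule stays the same.

Going by the values given here, the one measured step at this place (a 1.2-fold lower number from compound 1 to compound 2 (0.09 log units; within the scatter)) exchanged 1-benzothiophen-5-yl for 1,3-benzothiazol-5-yl and stayed within the scatter. Among the compounds with values here, no measured compound carries 2-methyl-1,3-benzoxazol-5-yl, and a single step is thin guidance. Going by that step to compound 2, no change beyond the scatter is expected in this assay, with an estimated size of a 1.1-fold higher number from compound 2 to compound 3 (0.03 log units; within the scatter) for this swap.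

Compound 3 is estimated at 42 mL.min-1.g-1 with an expected range of 20 mL.min-1.g-1 to 85 mL.min-1.g-1 in this measurement.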

Compound 3, intrinsic clearance in microsomes: < 14 mL.min-1.g-1
Compound 3 ended at the assay's limit (the forecaster's own chance of this, stated with the estimate: 2%); middle value at least 3.0-fold (0.47 log units) away from the limit.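

Until now, the group at this position had made no difference beyond the scatter in this assay, but 2-methyl-1,3-benzoxazol-5-yl gives an at least 2.7-fold lower number from compound 2 to compound 3 (0.44 log units; beyond the scatter), so a change here can alter how fast the compound is removed. Set against 1-benzothiophen-5-yl, the same group gives an at least 3.4-fold lower number from compound 1 to compound 3 (0.53 log units; beyond the scatter), which places it apart from both earlier groups, while those two stay level with each other. The value of compound 3 is a limit of the assay and not a number: the limit of < 14 mL.min-1.g-1 in this assay, at which 1 of the 3 values shown sits.

The swap brings two differences at once, an oxygen in place of a sulfur in the five-membered ring and an added methyl group, and the compounds shown cannot tell which of these goes with the lower number. From the compounds shown here alone, a 1,3-benzoxazol-5-yl group without the methyl, or a 2-methyl-1,3-benzothiazol-5-yl group, would pull the two apart at this position, and how far below the limit the true number lies also stays open.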